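This account rests on a few compounds, and the source may have more. Where it says the series, first, only, none or still open, it means among the compounds named here.

Of the compounds shown here, two that share one core have so far been measured in a functional assay on MGC-803 cells (Homo sapiens) for inhibition, read by MTT assay, with a stated time of 72 h; a lower number here means a stronger inhibitor, a higher number a weaker inhibitor. Compound 1 `C=CC(=O)Nc1cccc(NC(=O)CSc2nc(Nc3ccccc3Br)c3ccccc3n2)c1` carries a 2-bromophenyl group on a nitrogen on an aromatic ring, and in this assay compound 1 gives 12800 nM. Compound 2 `C=CC(=O)Nc1cccc(NC(=O)CSc2nc(Nc3ccc(F)cc3)c3ccccc3n2)c1` has 4-fluorophenyl in place of 2-bromophenyl on that same nitrogen, and in this assay compound 2 gives 8290 nM. The step of a 1.5-fold lower number from compound 1 to compound 2 (0.19 log units; within the scatter) is the only one recorded, and it lies within the scatter, so these two numbers cannot be separated; compound 2 stands at the lowest of the two numbers, with compound 1 nearest to it.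

Compound 3 `C=CC(=O)Nc1cccc(NC(=O)CSc2nc(Nc3ccc(Br)cc3)c3ccccc3n2)c1` has not yet been measured. It differs from compound 2 by bromo in place of fluoro on an aromatic carbon. Within the data shown here, no measured step bears directly on this exchange of one halogen for another on the same aromatic carbon; the only step recorded changed both the halogen and where it sits, and stayed within the scatter. The expected step is therefore a 1.3-fold lower number from compound 2 to compound 3 (0.11 log units; within the scatter), which is no larger than the scatter. Compound 3 is estimated at 6500 nM, with a range from 2500 nM to 16000 nM.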

Compound 3, half-maximal inhibitory concentration: 11500 nM
The estimate for compound 3 lay 1.8-fold (0.25 log units) below the measured number; low and high end bracket the measured number.
By their numbers in this assay, from the lowest: compounds 2, 3 and 1 (each within the scatter of the next).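

Putting bromo in place of fluoro on the same aromatic carbon, with nothing else altered, gives a 1.4-fold higher number from compound 2 to compound 3 (0.14 log units; within the scatter) in this assay, so this exchange of one halogen for another leaves no difference that can be read. With the halogen kept as bromo, 4-bromophenyl in place of 2-bromophenyl on the same nitrogen gives a 1.1-fold lower number from compound 1 to compound 3 (0.05 log units; within the scatter), so a change in where the bromo sits also leaves no readable difference. The earlier step had changed the halogen and its place together, and these two steps now test each change alone, although no measurement shown accounts for how close the three numbers lie.

From the compounds shown here alone, all three compounds carry a single halogen on this phenyl ring, so it remains open whether a methoxy group, an amine or a carboxylic acid on that same aromatic carbon would give a number beyond the scatter. The rest of the structure is the same throughout, which also leaves open what a longer chain between the sulfur and the amide carbonyl would do.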